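A Dioxolane-Methyl Handle in Place of Benzyl

A few compounds are considered here, and "the series" means these few. Any claim that something is new, unique, unknown or untested is made for them only; others in the source may bear on it.

Three compounds have been measured in a functional assay on B16 cells (Mus musculus) for cytotoxicity, read by MTT assay, with a stated time of 48 h; on this read-out lower numbers stand for stronger inhibition and higher numbers for weaker inhibition:

compound 1 `Cc1ccc(C(O)c2cn(CC3COC(C)(C)O3)nn2)cc1`: > 100000 nM
compound 2 `Cc1ccc(C(O)c2cn(Cc3ccccc3)nn2)cc1`: > 100000 nM
compound 3 `OC(c1ccc2ccccc2c1)c1cn(Cc2ccccc2)nn1`: 28800 nM

The value for compound 1 is a limit of this assay, not a number. The value for compound 2 is likewise a limit. Among the measured compounds shown here, compound 3 gives the only number, and in this assay compound 3 sits at 28800 nM.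

Compound 2 and compound 1 differ in one place, (2,2-dimethyl-1,3-dioxolan-4-yl in place of phenyl on a saturated chain carbon bound to an aromatic nitrogen). The step that the two limits leave unreadable from compound 2 to compound 1 cannot be read because of the limit of > 100000 nM in this assay, at which 2 of the 3 values shown sit. How the core of compound 3 differs from that of compound 2 is not broken down here.

Compound 4 `CC1(C)OCC(Cn2cc(C(O)c3ccc4ccccc4c3)nn2)O1` differs from compound 3 by 2,2-dimethyl-1,3-dioxolan-4-yl in place of phenyl on a saturated chain carbon bound to an aromatic nitrogen, the same change made from compound 2 to compound 1, at the same place. What that change did in this assay is not known, since the step that the two limits leave unreadable from compound 2 to compound 1 stays hidden behind (the limit of > 100000 nM in this assay, at which 2 of the 3 values shown sit). The expectation for compound 4 therefore rests on compound 3 at 28800 nM alone, and the step of a 1.6-fold higher number from compound 3 to compound 4 (0.19 log units; within the scatter) is expected to be small with a wide spread. Compound 4 is estimated at 45000 nM in this assay, between 12000 nM and 100000 nM.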

Compound 4, half-maximal inhibitory concentration: 26900 nM
The estimate for compound 4 lay 1.7-fold (0.22 log units) above the measured number; measured number inside the range.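

In this assay, replacing benzyl with (2,2-dimethyl-1,3-dioxolan-4-yl)methyl gives a 1.1-fold lower number from compound 3 to compound 4 (0.03 log units; within the scatter), so on the core of compound 3 the two groups cannot be told apart in this read-out. The same change on the other core, taking compound 2 to compound 1, cannot be read, because neither compound has a number to compare, only a limit of the assay: the limit of > 100000 nM in this assay, at which 2 of the 4 values shown sit. This gives one readable pair on one core, which shows that the exchange can be made on the core of compound 3 without a visible step, but does not show that it would behave the same way on any other core.

Still open, from the compounds shown here alone, is what an amine or a carboxylic acid would do on a saturated chain carbon bound to an aromatic nitrogen, on either core. The compounds shown also leave open whether the match between compound 3 and compound 4 would hold on a core giving numbers well clear of the limit.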